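Shortening the Carbonyl Chain of Compound 1

A few compounds are considered here, and "the series" means these few. Any claim that something is new, unique, unknown or untested is made for them only; others in the source may bear on it.

Compound 1 `CCCC(=O)n1c(=S)[nH]c2ccccc21` – 190000 nM
Compound 2 `O=C(c1cccc(Cl)c1)n1c(=S)[nH]c2ccccc21` – 400000 nM

Both compounds were tested in a physicochemical assay for solubility (a higher number here means a more soluble compound, a lower number a less soluble compound), and compound 1 has the lower of the two numbers. Compound 2 stands above it by more than the usual scatter of repeated measurements.

The next molecule, compound 3 `CC(=O)n1c(=S)[nH]c2ccccc21`, has not yet been measured. It differs from compound 1 in one place: hydrogen in place of ethyl on a saturated chain carbon bound to a carbonyl carbon. In words, hydrogen takes the place of ethyl on a saturated chain carbon bound to a carbonyl carbon, so that propylcarbonyl becomes acetyl while the shared core stays the same.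

For the measured compounds named here, no pair of measured compounds shows this change, so any forecast for this assay is a judgement from the structures alone. A modest rise seems most likely, although a result within the scatter would be no surprise. The estimated change is a 1.6-fold higher number from compound 1 to compound 3 (0.20 log units; within the scatter), a step expected to be small. For compound 3 the estimated value is 300000 nM, with an expected range from 130000 nM to 700000 nM. Going by the values given here, the range is kept wide, as only two measured values exist.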

Compound 3, solubility: 460000 nM
For compound 3 the middle estimate is 1.5-fold (0.19 log units) below the measured one; the measured number falls inside the stated range.
By their numbers in this assay, from the lowest: compound 1; then compounds 2 and 3 (each within the scatter of the next).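

Replacing ethyl with hydrogen on a saturated chain carbon bound to a carbonyl carbon turns propylcarbonyl into acetyl and gives a 2.4-fold higher number from compound 1 to compound 3 (0.38 log units; beyond the scatter) in this assay on the shared core. For the compounds shown here, this is the first direct reading of a change at this position, and it shows that the number responds to this group: the step is modest, but it lies beyond the usual scatter. No separate measurement is available to account for the rise, so the result records what happened without explaining it.

A single step gives only two points at this position, so it cannot show whether the number would keep moving in the same direction or how it would behave along a series of chain lengths. Still open, from the compounds shown here alone, is how this assay would read with methyl in the same place, which would fall between hydrogen and ethyl, or with a longer chain, an amine or a carboxylic acid on that carbon.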